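Removing the Hydroxy Group from Compound 3

This account rests on a few compounds, and the source may have more. Where it says the series, first, only, none or still open, it means among the compounds named here.

Values measured so far in a physicochemical assay for lipophilicity, measured as octanol-water partition; a higher number here means a more lipophilic compound, a lower number a more polar compound
- Compound 1 `CC1=C(C(=O)OCc2ccccn2)C(c2cccc(O)c2)C2=C(CCCC2=O)N1` gives 1.58
- Compound 2 `CCCC1C(C(=O)OCc2ccccn2)=C(C)NC2=C1C(=O)CCC2` gives 2.6
- Compound 3 `CC1=C(C(=O)OCc2ccccn2)C(c2ccc(O)cc2)C2=C(CCCC2=O)N1` gives 1.58

In this assay compound 3 stands level with compound 1, the two together the lowest of the three, while compound 2 is furthest away, with a number 1.02 log units lower from compound 2 to compound 3 (beyond the scatter).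

Compound 4 `CC1=C(C(=O)OCc2ccccn2)C(c2ccccc2)C2=C(CCCC2=O)N1` is not yet measured. It differs from compound 3 in one place: hydrogen in place of hydroxy on an aromatic carbon. This is hydrogen in place of hydroxy on an aromatic carbon, para to a large group, so 4-hydroxyphenyl becomes phenyl.

Among the compounds with values here, no measured step makes exactly this change, so the evidence is indirect. Shifting the hydroxy gave no change at the digits printed from compound 1 to compound 3 (within the scatter) and offers no guide to removing it. Exchanging the whole 3-hydroxyphenyl for propyl gave a number 1.02 log units higher from compound 1 to compound 2 (beyond the scatter), and compound 2, which carries no hydroxy, gives 2.6 in this assay. That single comparison points upward, but it changes far more than the present step, which keeps the aromatic ring. A moderate rise beyond the scatter, smaller than that large step, is therefore expected, estimated as a number 0.62 log units higher from compound 3 to compound 4 (beyond the scatter).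

For compound 4 the estimated value is 2.2, with an expected range from 1.85 to 2.6.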

Compound 4, partition coefficient: 2.72
Compound 4: middle estimate off by 0.52 log units, on the low side; the whole stated range lies below it.
By their numbers in this assay, from the lowest: compounds 1 and 3 (each within the scatter of the next); then compounds 2 and 4 (each within the scatter of the next).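

In this assay, within the data shown here, the first direct reading of this change shows it to be large: hydrogen in place of hydroxy gives a number 1.14 log units higher from compound 3 to compound 4 (beyond the scatter), and the same exchange starting from the 3-hydroxyphenyl group gives a number 1.14 log units higher from compound 1 to compound 4 (beyond the scatter), so the size of the step is the same from either of the two hydroxyphenyl compounds. With the hydroxy gone, phenyl in place of propyl on the saturated ring carbon gives a number 0.12 log units higher from compound 2 to compound 4 (within the scatter), so among these four compounds the large gap that first appeared between propyl and the hydroxyphenyl groups tracks the hydroxy and not the aromatic ring as such. Nothing shown here speaks to the reason the removal of this one group counts for so much in this assay.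

What the compounds shown leave open is how other groups on this aromatic carbon, such as a methoxy group, a fluorine atom or an amine, would stand against compound 3 and compound 4 in this assay. From the compounds shown here alone, it also remains open whether a longer chain or a smaller alkyl group in place of propyl would stay level with the phenyl of compound 4.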